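Replacing ureido with piperazin-1-yl: compound 3 awaits measurement

The compounds below may be only part of what the source reports. "The series", "measured", "known", "first", "only" and "open" are said of these compounds alone.

Measured in a functional assay on KB cells (Homo sapiens) for cytotoxicity, read by MTT assay, with a stated time of 3 days; a lower number here means a stronger inhibitor, a higher number a weaker inhibitor:
Compound 1 `N#Cc1c(NNC(N)=S)nc(SCc2nc3ccccc3[nH]2)nc1-c1ccccc1` gives 3 nM
Compound 2 `N#Cc1c(NC(N)=O)nc(SCc2nc3ccccc3[nH]2)nc1-c1ccccc1` gives 9.6 nM
Compound 3 `N#Cc1c(-c2ccccc2)nc(SCc2nc3ccccc3[nH]2)nc1N1CCNCC1` has not yet been measured

Compound 2 holds the higher of the two numbers in this assay, at 9.6 nM. Compound 3 carries piperazin-1-yl in place of ureido on an aromatic carbon. Among the measured compounds shown here, only one measured step bears on this, a change within the group that now leaves: a 3.2-fold higher number from compound 1 to compound 2 (0.51 log units; beyond the scatter). For the measured compounds named here, that step was modest, and no measured compound yet has a ring at this place, so a modest rise in the number is expected, though the direction remains uncertain. The expected step is a 2.1-fold higher number from compound 2 to compound 3 (0.32 log units; beyond the scatter). Compound 3 is estimated at 20 nM, with an expected range from 4 nM to 100 nM.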

Compound 3, half-maximal inhibitory concentration: 2.87 nM
For compound 3 the middle estimate is 7.0-fold (0.84 log units) above the measured one; measured number outside the range, below it.
By their numbers in this assay, from the lowest: compounds 3 and 1 (each within the scatter of the next); then compound 2.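

In this assay, this position takes a ring: piperazin-1-yl, the first six-membered non-aromatic ring on this aromatic carbon, in place of ureido gives a 3.3-fold lower number from compound 2 to compound 3 (0.52 log units; beyond the scatter). Set against the open-chain group of compound 1, the same ring gives a 1.0-fold lower number from compound 1 to compound 3 (0.02 log units; within the scatter), so a ring and an open chain sit level here. Nothing measured accounts for the gain over ureido. As far as these compounds go, whether morpholin-4-yl or a plain dimethylamino group would hold this level remains open. So does the part played by the second ring nitrogen of piperazin-1-yl.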